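A few compounds are considered here, and "the series" means these few. Any claim that something is new, unique, unknown or untested is made for them only; others in the source may bear on it.

Within the data shown here, in an ADME assay on MDCK cells (Canis lupus familiaris) for cytotoxicity, read by MTT assay, with a stated time of 24 h (on this read-out higher numbers stand for lower toxicity in this test and lower numbers for higher toxicity in this test), only two compounds have entries so far. For compound 1 `Cc1cc(CNS(=O)(=O)c2ccc(F)cc2)c(C)s1` the result reads "not determined" (no result reported) and gives no number to compare. From the compounds shown here alone, compound 2 `O=[N+]([O-])c1ccc(S(=O)(=O)NCc2csc3ccccc23)cc1` gives > 191000 nM as its result, which is a limit of the assay and not a number, so its true position is unknown.

Compound 3 `N#Cc1ccc(S(=O)(=O)NCc2csc3ccccc23)cc1` keeps the core of compound 2 and changes one group: cyano in place of nitro on an aromatic carbon describes the swap, with cyano in place of nitro on an aromatic carbon, para to a large group. Among the measured compounds shown here, no measured pair shows what this swap does. For the measured compounds named here, the limit of compound 2 at > 191000 nM is the only guide, so no step beyond the usual scatter is expected in this assay in either direction. The expected size of the change is a step that the limit leaves unreadable from compound 2 to compound 3 in this estimate. Compound 3 is estimated at 200000 nM on this measure, with an expected range from 90000 nM to 400000 nM as the likely span.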

Compound 3, half-maximal cytotoxic concentration: 122000 nM
For compound 3 the middle estimate is 1.6-fold (0.21 log units) above the measured one; low and high end bracket the measured number.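

In this assay, among these compounds, compound 3 gives 122000 nM, the first single number for this core, so a compound with this shared core now has a readable position on the scale. Cyano in place of nitro on an aromatic carbon, para to a large group, gives an at least 1.5-fold lower number from compound 2 to compound 3 (0.19 log units; that floor lies within the scatter), which means the swap may change little, while a larger change also remains possible. The step can be stated only as a floor because compound 2 carries a limit of the assay: the limit of > 191000 nM in this assay, at which 1 of the 3 values shown sits.

From the compounds shown here alone, how far compound 3 truly lies from compound 2 stays open. So does what an amine, a carboxylic acid or a longer chain would give at this same place on the ring in this assay.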